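Aryl group swap in a quinolinone series: tolerance on MDCK cells

This account rests on a few compounds, and the source may have more. Where it says the series, first, only, none or still open, it means among the compounds named here.

Measured so far:
compound 1 `COc1ccc([C@H](C)N(Cc2ccc(C(C)(C)C)cc2)Cc2cc3ccccc3[nH]c2=O)cc1`: 1800 nM
compound 2 `COc1ccc([C@H](C)N(Cc2ccc(OC(F)(F)F)cc2)Cc2cc3ccccc3[nH]c2=O)cc1`: > 10000 nM
compound 3 `CC(c1ccc(N(C)C)c(Cl)c1)N(Cc1ccc(C(C)(C)C)cc1)Cc1cc2cc(Br)ccc2[nH]c1=O`: 6100 nM

In a toxicity assay on MDCK cells (Canis lupus familiaris) for cytotoxicity, read by crystal violet staining, with a stated time of 48 h (a lower number here means that less compound is tolerated, a higher number that more compound is tolerated), compound 1 gives 1800 nM. Compound 2 reaches only the limit of this assay, > 10000 nM, and is not a number; it sits at the limit of > 10000 nM in this assay, at which 1 of the 3 values shown sits. Between them is one change, (trifluoromethoxy in place of tert-butyl on an aromatic carbon), which made an at least 5.5-fold higher number from compound 1 to compound 2 (0.74 log units; beyond the scatter). Compound 3 gives 6100 nM in this assay; the difference between the cores of compound 1 and compound 3 is not broken down here. Compound 4 `CC(c1ccc(N(C)C)c(Cl)c1)N(Cc1ccc(OC(F)(F)F)cc1)Cc1cc2cc(Br)ccc2[nH]c1=O` carries the same change on the core of compound 3, (trifluoromethoxy in place of tert-butyl on an aromatic carbon), at the same place. The step is expected to be a 3.3-fold higher number from compound 3 to compound 4 (0.52 log units; beyond the scatter) because an at least 5.5-fold higher number from compound 1 to compound 2 (0.74 log units; beyond the scatter) ran upward into the limit. Compound 4 is therefore estimated at 20000 nM in this assay, most likely reported as a limit.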

Compound 4, half-maximal cytotoxic concentration: 4700 nM
Beside the measured number, compound 4's estimate is 4.3-fold (0.63 log units) above it, outside the stated range (below it).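

In this assay, trifluoromethoxy in place of tert-butyl on the core of compound 3 gives a 1.3-fold lower number from compound 3 to compound 4 (0.11 log units; within the scatter), so the change does not carry over in size from the core of compound 1: the same change on two cores in this assay, an at least 5.5-fold higher number (0.74 log units; beyond the scatter) from compound 1 to compound 2 and a 1.3-fold lower number (0.11 log units; within the scatter) from compound 3 to compound 4, at least 7.2-fold (0.85 log units) apart, beyond the scatter of two such steps

As far as these compounds go, compound 2 stands at a limit, > 10000 nM, and not a number, so the full size of the step on its core stays unknown. Two pairs also do not show which difference between the cores goes with the different outcome.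

Open, from the compounds shown here alone, is whether the bromine alone, or the chlorine and dimethylamino group, separate the two outcomes. Also open, going by these compounds, is how a carboxylic acid or a nitrile in place of tert-butyl would read on either core.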